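Trimethoxyphenyl triazoles: nitro-to-chloro swap on an inactive pair

The source may hold more compounds than are shown below. What is called first, only, known or untested is meant among the compounds shown, and "the series" means these compounds.

Compound 1 `COc1cc(-c2ncnn2-c2ccc([N+](=O)[O-])cc2)cc(OC)c1OC` is examined in a functional assay on HL-60 cells (Homo sapiens) for antiproliferative activity, read by MTT assay, with a stated time of 72 h; on this read-out higher numbers stand for weaker inhibition and lower numbers for stronger inhibition. In this assay compound 1 gives only a limit of the assay, > 10000 nM. Compound 2 `COc1cc(-c2ncnn2-c2ccc(Cl)cc2)cc(OC)c1OC` differs from compound 1 by chloro in place of nitro on an aromatic carbon. In this assay compound 2 likewise reaches only a limit, > 10000 nM. The step that the two limits leave unreadable from compound 1 to compound 2 therefore cannot be sized. Compound 3 `COc1cc(-n2ncnc2-c2cccc([N+](=O)[O-])c2)cc(OC)c1OC` has the same atoms as compound 1 joined differently; the difference between the two cores is not broken down here. In this assay compound 3 also shows only a limit, > 10000 nM. Compound 4 `COc1cc(-n2ncnc2-c2cccc(Cl)c2)cc(OC)c1OC` is not yet measured and differs from compound 3 by chloro in place of nitro on an aromatic carbon. Going by the values given here, this is the same kind of change as the one between compound 1 and compound 2, though there the chloro sits para to a large group and here meta to a large group. Because the limit of > 10000 nM in this assay, at which 3 of the 3 values shown sit, holds for every value shown, the step that the limit leaves unreadable from compound 3 to compound 4 is expected to remain unreadable as well. Compound 4 is expected to give 15000 nM, within a range from 5000 nM to 50000 nM, most probably again as a limit.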

Compound 4, half-maximal inhibitory concentration: > 10000 nM
Compound 4 gave a limit, no number; the forecaster's own chance of this, stated with the estimate: 85%; the middle value does not contradict the limit.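

Compound 3 and compound 4 both give only a limit, so no step can be read between them: the limit of > 10000 nM in this assay, at which 4 of the 4 values shown sit. The compounds shown leave open whether chloro in place of nitro changes activity on either core, and how the two cores compare.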